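Swapping a chloro-phenyl for a furan ring

This account rests on a few compounds, and the source may have more. Where it says the series, first, only, none or still open, it means among the compounds named here.

Compound 1 `CC1=CC[C@H](C(C)(C)NC(=S)NN)CC1`: > 100000 nM (a limit).
Compound 2 `CC1=CC[C@H](C(C)(C)NC(=S)N/N=C/c2ccc(O)cc2)CC1`: > 100000 nM (a limit).
Compound 3 `CC1=CC[C@H](C(C)(C)NC(=S)N/N=C/c2cccc(Cl)c2)CC1`: 80500 nM.

Going by the values given here, in a functional assay on OVCAR-3 cells (Homo sapiens) for inhibition, read by sulforhodamine B assay, with a stated time of 48 h (a lower number here means a stronger inhibitor of growth, a higher number a weaker inhibitor of growth), compound 3 gives the only definite number of the three; the other two compounds stop at the limit of > 100000 nM in this assay, at which 2 of the 3 values shown sit. Among the compounds with values here, the one measured step, an at least 1.2-fold lower number from compound 2 to compound 3 (0.09 log units; that floor lies within the scatter), is a floor that lies within the scatter, so it says little about how the group on the carbon with a double bond to nitrogen steers potency. Compound 4 `CC1=CC[C@H](C(C)(C)NC(=S)N/N=C/c2ccco2)CC1` carries furan-2-yl in place of 3-chlorophenyl on a carbon with a double bond to nitrogen. Within the data shown here, no measured step bears on this change, so no shift beyond the scatter is expected, and the weak activity of compound 3 leaves room for the reading to become a limit again. The estimate for compound 4 is 100000 nM, within 40000 nM to 250000 nM, an expected step of a 1.2-fold higher number from compound 3 to compound 4 (0.09 log units; within the scatter).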

Compound 4, concentration for total growth inhibition: 13800 nM
Beside the measured number, compound 4's estimate is 7.2-fold (0.86 log units) above it; measured number outside the range, below it.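

In this assay, going by these compounds alone, the group on a carbon with a double bond to nitrogen clearly affects growth inhibition: furan-2-yl in place of 3-chlorophenyl gives a 5.8-fold lower number from compound 3 to compound 4 (0.77 log units; beyond the scatter), the first step here beyond the scatter. The other two steps also lie beyond the scatter, an at least 7.2-fold lower number from compound 2 to compound 4 (0.86 log units; beyond the scatter) and an at least 7.2-fold lower number from compound 1 to compound 4 (0.86 log units; beyond the scatter), but they give only minimum sizes because two compounds sit at a limit: the limit of > 100000 nM in this assay, at which 2 of the 4 values shown sit.

From the compounds shown here alone, whether the furan oxygen or the smaller ring matters more stays open. A thiophen-2-yl or an unsubstituted phenyl group at this place could help separate the two.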